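The source may report more compounds than this note shows. Statements on the series, on what has been measured and on what is new or still open speak of the compounds shown alone.

Going by the values given here, in a physicochemical assay for solubility, at pH 7.4 (on this read-out higher numbers stand for higher solubility and lower numbers for lower solubility), compound 1 `OCCc1nc(Nc2ccc(C(F)(F)F)cc2)c2ccc(-c3ncccc3C(F)(F)F)cc2n1` gives 0.02 ug/mL and compound 2 `CS(=O)(=O)CCc1nc(Nc2ccc(C(F)(F)F)cc2)c2ccc(-c3ncccc3C(F)(F)F)cc2n1` gives 0.2 ug/mL as the higher of the two numbers so far. Compound 3 `CNCc1nc(Nc2ccc(C(F)(F)F)cc2)c2ccc(-c3ncccc3C(F)(F)F)cc2n1` alters the same chain on the shared core, and methylamino in place of (methylsulfonyl)methyl on a saturated chain carbon bound to an aromatic carbon sums up that change: methylamino in place of (methylsulfonyl)methyl on a saturated chain carbon bound to an aromatic carbon. Among the compounds with values here, only one measured step bears on it, the move a 10-fold higher number from compound 1 to compound 2 (1.00 log units; beyond the scatter) which is modest but lies beyond the scatter. A single step at this chain sets no rule for a new group, so the size stays uncertain, yet a further rise of similar modest size is expected in this assay for the new structure. The step expected is a 5.0-fold higher number from compound 2 to compound 3 (0.70 log units; beyond the scatter) by this estimate. For compound 3 the estimate is 1 ug/mL with an expected range from 0.1 ug/mL to 15 ug/mL as a rough expectation.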

Compound 3, solubility: 10 ug/mL
The estimate for compound 3 lay 10-fold (1.00 log units) below the measured number; low and high end bracket the measured number.
By their numbers in this assay, from the lowest: compound 1; then compound 2; then compound 3.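

In this assay, the chain on the saturated carbon bound to an aromatic carbon proves able to move the number much further than the first pair showed: there is a 50-fold higher number from compound 2 to compound 3 (1.70 log units; beyond the scatter) and a 500-fold higher number from compound 1 to compound 3 (2.70 log units; beyond the scatter), and both are large beside the modest 10-fold higher number from compound 1 to compound 2 (1.00 log units; beyond the scatter). Among these three compounds, the one carrying methylamino stands highest, but going from 2-(methylsulfonyl)ethyl to (methylamino)methyl changes the end group and the chain length together. Nothing available here accounts for the rise.

The compounds shown cannot separate those two changes, and 2-(methylamino)ethyl on the same core would speak to that directly. Going by these compounds, whether the hydrogen on the nitrogen matters also stays open, a question that dimethylamino in place of methylamino would address.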